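The compounds below may be only part of what the source reports. "The series", "measured", "known", "first", "only" and "open" are said of these compounds alone.

Compound 1 `COc1ccc(-c2noc(-c3ccccc3)n2)cc1OC1CCCC1` was tested in a functional assay on MIA PaCa-2 cells (Homo sapiens) for antiproliferative activity, read by MTT assay, with a stated time of 24 h; a lower number here means a stronger inhibitor, a higher number a weaker inhibitor. In this assay compound 1 gives > 1000000 nM, which is a limit of the assay rather than a measured number. That limit is the point described in the limit of > 1000000 nM in this assay, at which 1 of the 2 values shown sits, so compound 1 stands as a very weak inhibitor, with no finer value to place it.

Going by the values given here, a second measured compound, compound 2 `COc1ccc(-c2noc(-c3ccc(F)cc3)n2)cc1O`, differs from compound 1 in more than one place, and no step between the two is given. In this assay compound 2 gives 351000 nM, a number rather than a limit.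

Compound 3 `COc1ccc(-c2noc(-c3cccnc3)n2)cc1OC1CCCC1` has not yet been measured. It differs from compound 1 by a single change: pyridin-3-yl in place of phenyl on an aromatic carbon. Nothing measured here shows what such a change does, so the expected step in this assay from compound 1 to compound 3 is small, within the usual scatter, with the outcome as likely to be another limit as a number. The estimate for compound 3 is 900000 nM, within a range from 200000 nM to 5000000 nM, which is the expected step of an at least 1.1-fold lower number from compound 1 to compound 3 (0.04 log units; that floor lies within the scatter).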

Compound 3, half-maximal inhibitory concentration: > 1000000 nM
Compound 3 was reported as a limit; the forecaster's own chance of this, stated with the estimate: 55%; middle value at least 1.1-fold (0.04 log units) away from the limit.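

In this assay compound 3 gives > 1000000 nM, which is a limit of the assay and not a number. Going by these compounds alone, compound 1 also stands at a limit, so no step between compound 1 and compound 3 can be read: the limit of > 1000000 nM in this assay, at which 2 of the 3 values shown sit. The compounds shown leave open what pyridin-3-yl in place of phenyl does to the potency in this assay.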